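Replacing 1H-pyrrol-2-yl with 4-(dimethylamino)phenyl

The source may hold more compounds than are shown below. What is called first, only, known or untested is meant among the compounds shown, and "the series" means these compounds.

Compound 1 `Cc1cc(C(=O)NCc2ccc3cc(C(=O)NO)sc3c2F)oc1C`: 470 nM
Compound 2 `O=C(NCc1ccc2cc(C(=O)NO)sc2c1F)c1ccc[nH]1`: 300 nM

Both values come from a functional assay on HCT-116 cells (Homo sapiens) for antiproliferative activity, read by resazurin assay, with a stated time of 5 days; on this read-out lower numbers stand for stronger inhibition and higher numbers for weaker inhibition. Among the measured compounds shown here, compound 2 stands level with compound 1, the only other measured compound: a 1.6-fold lower number from compound 1 to compound 2 (0.19 log units; within the scatter). Compound 3 `CN(C)c1ccc(C(=O)NCc2ccc3cc(C(=O)NO)sc3c2F)cc1` shares their core and has not yet been measured in this assay. Its difference from compound 2 is 4-(dimethylamino)phenyl in place of 1H-pyrrol-2-yl on a carbonyl carbon. For the measured compounds named here, only one measured step bears on this change, since it also exchanges the group on that carbonyl carbon, putting 1H-pyrrol-2-yl in place of 4,5-dimethylfuran-2-yl: a 1.6-fold lower number from compound 1 to compound 2 (0.19 log units; within the scatter). A single step is thin evidence, and it says nothing direct about 4-(dimethylamino)phenyl. No shift beyond the scatter is therefore expected in this assay, in either direction. The expected step is a 1.2-fold higher number from compound 2 to compound 3 (0.07 log units; within the scatter). For compound 3 the estimate is 350 nM, with an expected range from 110 nM to 1100 nM.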

Compound 3, half-maximal inhibitory concentration: 60 nM
Compound 3: the middle estimate sits 5.8-fold (0.77 log units) above what was measured, and the stated range ends above it.
By their numbers in this assay, from the lowest: compound 3; then compounds 2 and 1 (each within the scatter of the next).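

In this assay, the group on this carbonyl carbon can move the number beyond the scatter, which the earlier exchange of compound 1 for compound 2 did not show. Putting 4-(dimethylamino)phenyl in place of 1H-pyrrol-2-yl gives a 5.0-fold lower number from compound 2 to compound 3 (0.70 log units; beyond the scatter) as the step, and putting it in place of 4,5-dimethylfuran-2-yl gives a 7.8-fold lower number from compound 1 to compound 3 (0.89 log units; beyond the scatter) as the step, so the gain holds against both earlier groups. Nothing measured here explains this gain.

The change swaps a five-membered aromatic ring for a six-membered one and adds a dimethylamino group in one move, so the compounds shown leave open which of these goes with the lower number. A plain phenyl group and a 4-aminophenyl group on the same carbonyl carbon would help to pull these two parts apart.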